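The source may report more compounds than this note shows. Statements on the series, on what has been measured and on what is new or still open speak of the compounds shown alone.

Measured so far in an in vitro functional assay on HEK293-A cells for antagonist activity at metabotropic glutamate receptor 5 (Rattus norvegicus), read by calcium flux; on this read-out higher numbers stand for weaker inhibition and lower numbers for stronger inhibition:
- compound 1, `N#Cc1cc(F)cc(C(=O)Nc2cccnc2)c1`: > 30000 nM
- compound 2, `N#Cc1cc(F)cc(C(=O)Nc2cccc(C(F)(F)F)n2)c1`: > 10000 nM

Compound 1 gives > 30000 nM in this assay, which is a limit of the assay and not a number; it sits at the limit of > 30000 nM in this assay, at which 1 of the 2 values shown sits. Compound 2 gives > 10000 nM in this assay, again a limit, at the limit of > 10000 nM in this assay, at which 1 of the 2 values shown sits. So no numbered inhibition has been recorded for either compound, and there is no measured step in the series to set a scale. Where compound 1 stands can only be said as: at the limit, with compound 2 also at a limit.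

Compound 3, `Cc1cnc(NC(=O)c2cc(F)cc(C#N)c2)s1`, remains to be measured. It differs from compound 1 by 5-methyl-1,3-thiazol-2-yl in place of pyridin-3-yl on an amide-type nitrogen. With both shown values being limits, no direction for this change can be read from the data. The step of an at least 2.0-fold lower number from compound 1 to compound 3 (0.30 log units; that floor lies within the scatter) is expected to lie within the scatter, with a real chance that the assay again reports only a limit. Compound 3 is expected at 15000 nM in this assay, in the range 1500 nM to 60000 nM.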

Compound 3, half-maximal inhibitory concentration: 863 nM
Estimate against measurement, compound 3: 17-fold (1.24 log units) above, and the stated range ends above it.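

In this assay, within the data shown here, the group on the amide-type nitrogen proves able to decide whether the shared core gives a numbered inhibition: 5-methyl-1,3-thiazol-2-yl in place of pyridin-3-yl gives an at least 34-fold lower number from compound 1 to compound 3 (1.54 log units; beyond the scatter), and compound 3 at 863 nM supplies the first value that is not a limit. Compound 1 gives > 30000 nM, a limit of the assay and not a number, so this step is a floor and its full size remains unknown: the limit of > 30000 nM in this assay, at which 1 of the 3 values shown sits. Compound 2 gives > 10000 nM, also a limit of the assay, so a numbered inhibition at this place is so far seen only with the 5-methyl-1,3-thiazol-2-yl group: the limit of > 10000 nM in this assay, at which 1 of the 3 values shown sits.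

Still open, going by these compounds, is whether the inhibition of compound 3 follows the methyl group or the five-membered aromatic ring itself; an unsubstituted 1,3-thiazol-2-yl group, or an ethyl group in place of the methyl, would separate the two. Also open, on these data alone, is how much the nitrile of the shared core contributes with this group in place, which a carboxylic acid or an amine at that place would test.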